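The source may report more compounds than this note shows. Statements on the series, on what has been measured and on what is new or still open speak of the compounds shown alone.

Compound 3 `Cc1cc(C)c(NC(=O)N(Cc2ccc(-c3cccnc3)cc2)C2CCCCCC2)c(C)c1` is the only one of the three measured compounds for which a functional assay on a cell-free system (plasma) with sterol O-acyltransferase, Soat (Rattus norvegicus) as the target (a lower number here means that less compound is needed, a higher number that more compound is needed for the effect), gives a number: compound 3 gives 0.58 mg/kg. Compound 1 `Cc1cc(C)c(NC(=O)N(Cc2ccc(-c3n[nH]c(C)n3)cc2)C2CCCCCC2)c(C)c1` reaches only a limit of this assay, > 1 mg/kg. Compound 2 `Cc1cc(C)c(NC(=O)N(Cc2ccc(-c3ccccn3)cc2)C2CCCCCC2)c(C)c1` likewise reaches only a limit, > 1 mg/kg. Compound 4 `Cc1cc(C)c(NC(=O)N(Cc2ccc(-c3cc[nH]n3)cc2)C2CCCCCC2)c(C)c1` differs from compound 3 by 1H-pyrazol-3-yl in place of pyridin-3-yl on an aromatic carbon. The measured steps that bear on this are an at least 1.7-fold lower number from compound 1 to compound 3 (0.23 log units; that floor lies within the scatter) and an at least 1.7-fold lower number from compound 2 to compound 3 (0.23 log units; that floor lies within the scatter); both end at compound 3, and both start from compounds sitting at the limit of > 1 mg/kg in this assay, at which 2 of the 3 values shown sit. Compound 1 also carries a five-membered ring with a hydrogen on nitrogen, like the ring that enters in compound 4, so the step of a 2.6-fold higher number from compound 3 to compound 4 (0.41 log units; beyond the scatter) is expected to run toward a higher number, possibly back to a limit. Compound 4 is therefore estimated at 1.5 mg/kg, with a range from 0.6 mg/kg to 4 mg/kg.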

Compound 4, dose for half-maximal effect: > 1 mg/kg
Compound 4: a limit, no number; the forecaster's own chance of this, stated with the estimate: 55%; the middle value is on the limit's open side.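

Putting 1H-pyrazol-3-yl in place of pyridin-3-yl gives an at least 1.7-fold higher number from compound 3 to compound 4 (0.23 log units; that floor lies within the scatter), so compound 4 joins compound 1 as a second compound with a five-membered ring bearing a hydrogen on nitrogen that reaches only a limit. The steps from compound 1 and compound 2 to compound 4 cannot be read, as all three values are limits. Of the four groups at this position, only pyridin-3-yl gives a number in this assay: the limit of > 1 mg/kg in this assay, at which 3 of the 4 values shown sit.

On these data alone, the true values behind these limits remain unknown, so those three groups cannot be ranked. As far as these compounds go, whether pyridin-4-yl or a plain phenyl ring would give a number also stays open.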